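This account rests on a few compounds, and the source may have more. Where it says the series, first, only, none or still open, it means among the compounds named here.

Among the measured compounds shown here, compound 1 `O=C(OC1CC1)N1CCc2cc(C3(C(=O)Nc4ccc(F)cc4)CCC3)ccc21` is the most potent of the three compounds measured so far. In an assay on HeLa cells for inhibition of Indoleamine 2,3-dioxygenase 1 (Homo sapiens) (a higher number here means a weaker inhibitor, a lower number a stronger inhibitor), compound 1 gives 1.4 nM, while compound 2 `O=C(NC1(c2ccc3c(n2)CCN3C(=O)OC2CC2)CCC1)c1ccc(Cl)cc1` gives 4.5 nM and compound 3 `O=C(Nc1ccc(F)cc1)C1(c2ccc3c(n2)CCN3c2ccccn2)CCC1` gives 10.9 nM, both beyond the usual scatter from compound 1. Compound 4 `O=C(Nc1ccc(F)cc1)C1(c2ccc3c(c2)CCN3c2ccccn2)CCC1` has not yet been measured. It differs from compound 1 in one place: pyridin-2-yl in place of cyclopropyloxycarbonyl on a nitrogen on an aromatic ring in a ring. For the measured compounds named here, no single-change step between measured compounds is known here, but compound 3 carries the same pyridin-2-yl group on a closely related core and gives 10.9 nM, so a shift toward weaker inhibition beyond the scatter is expected, a 3.6-fold higher number from compound 1 to compound 4 (0.55 log units; beyond the scatter). For compound 4 the expected value in this assay is 5 nM, with a likely range from 1.5 nM to 15 nM.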

Compound 4, half-maximal inhibitory concentration: 3.1 nM
Estimate against measurement, compound 4: 1.6-fold (0.21 log units) above; the measured number falls inside the stated range.
By their numbers in this assay, from the lowest: compound 1; then compounds 4 and 2 (each within the scatter of the next); then compound 3.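

In this assay the step of a 2.2-fold higher number from compound 1 to compound 4 (0.35 log units; beyond the scatter) is modest, although it replaces cyclopropyloxycarbonyl with a quite different group on the same ring nitrogen. This position therefore does not need the carbonyl or the three-membered ring for strong inhibition, since compound 4 with its pyridin-2-yl group still gives 3.1 nM in this assay. No measurement bears on why the change costs so little. Still open, on these data alone, is how a plain phenyl ring, a small acetyl group or a simple methyl would behave on this nitrogen.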